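Thiourea series: methyl on the fused ring

A few compounds are considered here, and "the series" means these few. Any claim that something is new, unique, unknown or untested is made for them only; others in the source may bear on it.

Compound 1, `S=C(Nc1ccc(Cl)cc1)Nc1nc2ccccc2s1`: in a functional assay on B16-F10 cells (Mus musculus) for cytotoxicity, read by MTT assay, with a stated time of 48 h (a higher number here means a weaker inhibitor, a lower number a stronger inhibitor), compound 1 reaches only the assay limit, > 50000 nM.
Compound 2, `Fc1ccc(NC(=S)Nc2nc3ccccc3s2)cc1`: in this assay compound 2 likewise gives only a limit, > 50000 nM.
Compound 3, `Cc1ccc2nc(Nc3nc4ccc(F)cc4s3)sc2c1`: in this assay compound 3 gives 29600 nM.

Compound 2 stands at the limit of > 50000 nM in this assay, at which 2 of the 3 values shown sit, so no number is known for it. The step from compound 1 to compound 2 is a step that the two limits leave unreadable from compound 1 to compound 2 and cannot be read. Compound 4, `Cc1ccc2nc(NC(=S)Nc3ccc(F)cc3)sc2c1`, differs from compound 2 by methyl in place of hydrogen on an aromatic carbon. Within the data shown here, no measured step shows what a methyl at this place does; compound 3 carries one on a different core and supplies the only real number in the set. The step of a number no higher from compound 2 to compound 4 (the limit leaves the size open) in this assay is therefore expected to be small, probably leaving compound 4 near the limit. Compound 4 is estimated at 50000 nM, with a range of 20000 nM to 150000 nM.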

Compound 4, half-maximal inhibitory concentration: > 50000 nM
Compound 4: only a limit was reported; the forecaster's own chance of this, stated with the estimate: 60%; the middle value sits exactly at the limit.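

Compound 4, like compound 2, gives only a limit, so the step between them cannot be read: the limit of > 50000 nM in this assay, at which 3 of the 4 values shown sit.

The compounds shown leave open whether methyl in place of hydrogen on this aromatic carbon changes anything in this assay.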